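Removing the Nitro Group: What Cytotoxicity May Show

This account rests on a few compounds, and the source may have more. Where it says the series, first, only, none or still open, it means among the compounds named here.

The measured compounds:
Compound 1 `O=C(COc1cccc2ccccc12)N/N=C/c1cccc([N+](=O)[O-])c1` gives >= 20 ug/mL in an ADME assay on HEL cells (Homo sapiens) for cytotoxicity; on this read-out lower numbers stand for higher toxicity in this test and higher numbers for lower toxicity in this test.
Compound 2 `Cc1ccc(/C=N/NC(=O)COc2cccc3ccccc23)cc1` gives 20 ug/mL in this assay.
Compound 3 `O=C(COc1cccc2ccccc12)N/N=C/c1ccc([N+](=O)[O-])cc1` gives 20 ug/mL in this assay.

The value of compound 1 is a limit of the assay, not a number (the limit of >= 20 ug/mL in this assay, at which 1 of the 3 values shown sits). Compound 3 stands level with compound 2 on the numbers shown: the step of no change at the digits printed from compound 2 to compound 3 (within the scatter) was no change within the scatter, with nitro in place of methyl on an aromatic carbon.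

Compound 4 `O=C(COc1cccc2ccccc12)N/N=C/c1ccccc1` has not yet been measured. It differs from compound 3 by hydrogen in place of nitro on an aromatic carbon.

Among the compounds with values here, the only measured step that bears on this change is the one from compound 2 to compound 3, which exchanged one group for another on the same aromatic carbon and left the minimum cytotoxic concentration unchanged. Since that exchange did nothing, the removal of the nitro group is expected to bring no step beyond the scatter, so the estimated step is no change at the digits printed from compound 3 to compound 4 (within the scatter). Compound 4 is therefore estimated to give 20 ug/mL in this assay, with a range from 10 ug/mL to 40 ug/mL.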

Compound 4, minimum cytotoxic concentration: 100 ug/mL
Compound 4: middle estimate off by 5.0-fold (0.70 log units), on the low side; measured number above the stated range.
By their numbers in this assay, from the lowest: compounds 2 and 3 (each within the scatter of the next); then compound 4.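

In this assay, the position on the aromatic ring turns out to matter: hydrogen in place of nitro gives a 5.0-fold higher number from compound 3 to compound 4 (0.70 log units; beyond the scatter), and hydrogen in place of methyl gives a 5.0-fold higher number from compound 2 to compound 4 (0.70 log units; beyond the scatter). The earlier exchange of methyl for nitro had shown no change, and only now is it clear that the difference lies between carrying either of these two groups and carrying hydrogen, with compound 4 at the higher number and so at lower toxicity in this test. The value of compound 1 is a limit, so its step to compound 4 cannot be read: the limit of >= 20 ug/mL in this assay, at which 1 of the 4 values shown sits.

From the compounds shown here alone, it remains open whether other groups at this place, such as an amine or a carboxylic acid, would stand level with compounds 2 and 3 or with compound 4. The compounds shown also do not tell what methyl and nitro share that sets compounds 2 and 3 apart from compound 4.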